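The source may hold more compounds than are shown below. What is called first, only, known or untested is meant among the compounds shown, and "the series" means these compounds.

The study measures cytotoxicity in a functional assay on MT4 cells (Homo sapiens) for cytotoxicity, read by MTT assay; a higher number here means that more compound is tolerated, a lower number that less compound is tolerated. Compound 1 `Cc1cc(C)cc(S(=O)(=O)c2c(C(=O)NCC(N)=O)[nH]c3ccc(Cl)cc23)c1` gives 45 uM in this assay. Compound 2 `CNNC(=O)c1[nH]c2ccc(Cl)cc2c1S(=O)(=O)c1cc(C)cc(C)c1` reaches only a limit of the assay in this assay, namely > 100 uM. The move between them is an at least 2.2-fold higher number from compound 1 to compound 2 (0.34 log units; beyond the scatter), and the higher of the two values rests on (the limit of > 100 uM in this assay, at which 1 of the 2 values shown sits), so compound 2 stands at the top of the numbers shown, with a bound rather than an exact figure of its own.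

Compound 3 `CC(=O)NNC(=O)c1[nH]c2ccc(Cl)cc2c1S(=O)(=O)c1cc(C)cc(C)c1` differs from compound 2 by acetyl in place of methyl on an amine nitrogen. Among the measured compounds shown here, only one measured step bears on this region of the molecule, the one an at least 2.2-fold higher number from compound 1 to compound 2 (0.34 log units; beyond the scatter), which exchanged the whole substituent on the amide-type nitrogen and raised the tolerated concentration to the limit. The change to compound 3 keeps that substituent and alters only the group on the amine nitrogen. For compound 3 the expected step is a number no higher from compound 2 to compound 3 (the limit leaves the size open) in this assay, that is, no movement beyond the scatter, with a value most likely again reported only as a limit. Compound 3 is therefore estimated at 100 uM, with a range from 50 uM to 200 uM.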

Compound 3, half-maximal toxic concentration: > 100 uM
Compound 3: no number, only a limit (the forecaster's own chance of this, stated with the estimate: 65%); the middle value lies on the limit itself.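

In this assay compound 3 again reaches only a limit of the assay, > 100 uM, so a second group on the amine nitrogen, this time acetyl rather than methyl, also gives no number. The exchange of carbamoylmethyl for acetamido on the amide-type nitrogen gives an at least 2.2-fold higher number from compound 1 to compound 3 (0.34 log units; beyond the scatter), so the shift first seen with methylamino is not confined to that one substituent, while compound 1 remains the only compound shown with a measured number. Acetyl and methyl on the amine nitrogen still cannot be ranked, and the step between compound 2 and compound 3 cannot be read because both compounds rest on the same ceiling: the limit of > 100 uM in this assay, at which 2 of the 3 values shown sit.

From the compounds shown here alone, how far the true values of compound 2 and compound 3 lie beyond that limit stays open, and so does any difference between them. The compounds shown also leave open how the same amine nitrogen would behave with a longer acyl chain such as butanoyl, or with a group carrying a carboxylic acid or a basic amine.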